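This account rests on a few compounds, and the source may have more. Where it says the series, first, only, none or still open, it means among the compounds named here.

In an ADME assay on MT4 cells (Homo sapiens) for cytotoxicity, read by MTT assay, with a stated time of 5 days (on this read-out lower numbers stand for higher toxicity in this test and higher numbers for lower toxicity in this test), compound 1 `COc1cc2nc(Nc3ccc(C#N)cc3)nc(Nc3c(F)cc(/C=C/C#N)cc3F)c2cc1OC` gives 6400 nM. Compound 2 `COc1cc2nc([S+]([O-])CC(=O)Nc3ccccc3F)nc(Nc3c(Cl)cc(/C=C/C#N)cc3Cl)c2cc1OC` gives > 208000 nM, which is a limit of the assay and not a number, so its true position on the scale is not known. Compound 3 `COc1cc2nc([S+]([O-])CC(=O)Nc3ccccc3C#N)nc(Nc3c(Cl)cc(/C=C/C#N)cc3Cl)c2cc1OC` has not yet been measured in this assay. It has cyano in place of fluoro on an aromatic carbon, ortho to a large group, so that 2-fluorophenyl becomes 2-cyanophenyl (cyano in place of fluoro on an aromatic carbon). Among the compounds with values here, no measured pair of compounds shows this change, and compound 2 is the only close reference. The expected step of an at least 1.3-fold lower number from compound 2 to compound 3 (0.14 log units; that floor lies within the scatter) is small, either none beyond the scatter or a modest move toward lower numbers. Compound 3 is expected to give about 150000 nM, with an estimated range of 40000 nM to 250000 nM.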

Compound 3, half-maximal cytotoxic concentration: > 206000 nM
Compound 3: a limit, no number; the forecaster's own chance of this, stated with the estimate: 60%; middle value at least 1.3-fold (0.13 log units) from the limit.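

In this assay, compound 2 and compound 3 each give only a limit of the assay and not a number, and no step can be read between them. The compounds shown leave open whether cyano in place of fluoro on this aromatic carbon changes the read-out at all.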